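From a carboxycyclopropyl to a dicarboxyethyl amide

This account rests on a few compounds, and the source may have more. Where it says the series, first, only, none or still open, it means among the compounds named here.

Measured in a functional assay on BXPC-3 cells (Homo sapiens) for antiproliferative activity, read by MTT assay, with a stated time of 24 h; on this read-out higher numbers stand for weaker inhibition and lower numbers for stronger inhibition:
- Compound 1 `CCn1c(C(=O)N[C@@H](C)C(=O)OC)ccc1C(CC)(CC)c1ccc(OCS(=O)(=O)c2ccccc2)c(C)c1`: 17900 nM
- Compound 2 `CCn1c(C(=O)N[C@H](C)C(=O)OC)ccc1C(CC)(CC)c1ccc(OCS(=O)(=O)c2ccccc2)c(C)c1`: > 50000 nM
- Compound 3 `CCn1c(C(=O)NC2(C(=O)O)CC2)ccc1C(CC)(CC)c1ccc(OCS(=O)(=O)c2ccccc2)c(C)c1`: > 50000 nM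

Compound 3 gives > 50000 nM, which is a limit of the assay and not a number. It therefore stands with compound 2 at the limit of > 50000 nM in this assay, at which 2 of the 3 values shown sit. Compound 4 `CCn1c(C(=O)N[C@H](CC(=O)O)C(=O)O)ccc1C(CC)(CC)c1ccc(OCS(=O)(=O)c2ccccc2)c(C)c1` carries 1,2-dicarboxyethyl in place of 1-carboxycyclopropyl on an amide-type nitrogen.

For the measured compounds named here, no measured step makes this exact change. The closest is an at least 2.7-fold higher number from compound 1 to compound 3 (0.44 log units; beyond the scatter), where 1-carboxycyclopropyl replaced 1-(methoxycarbonyl)ethyl. There is also an at least 2.7-fold higher number from compound 1 to compound 2 (0.44 log units; beyond the scatter), which rests on (the fact that compounds 1 and 2 differ only in the configuration as drawn), and compound 4 has a defined stereocentre. By contrast, a step that the two limits leave unreadable from compound 2 to compound 3 offers no size to use.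

With compound 3 starting from a limit, no real gain in strength is expected. The expected change in this assay is a step that the limit leaves unreadable from compound 3 to compound 4, and it may not be readable at all. Compound 4 is estimated at 60000 nM, with an expected range of 30000 nM to 120000 nM.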

Compound 4, half-maximal inhibitory concentration: > 50000 nM
Compound 4: no number, only a limit; the forecaster's own chance of this, stated with the estimate: 85%; the middle value does not contradict the limit.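

In this assay compound 4 gives > 50000 nM, which is a limit of the assay and not a number. The steps that join compound 4 to compound 2 and compound 3 therefore cannot be read, and the only readable one is an at least 2.7-fold higher number from compound 1 to compound 4 (0.44 log units; beyond the scatter). On this amide-type nitrogen, 1,2-dicarboxyethyl thus gives no measured value any more than 1-carboxycyclopropyl does, compound 2 with its ester goes against tying this to free acids alone, and the one number at this position stays with compound 1: the limit of > 50000 nM in this assay, at which 3 of the 4 values shown sit.

Going by these compounds, how far apart compound 2, compound 3 and compound 4 really lie stays open. Also open, on these data alone, is whether an amine or a longer ester chain on this nitrogen would give a number rather than a limit.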